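The compounds below may be only part of what the source reports. "The series", "measured", "known", "first", "only" and "open" are said of these compounds alone.

Compound 1 `COC(=O)c1cc(-c2cccc(NC(=O)c3ccc(/C=C/C(=O)c4ccc(F)cc4)cc3)c2)on1`: in an ADME assay on Vero cells (Chlorocebus sabaeus) for cytotoxicity, read by MTT assay, with a stated time of 72 h (on this read-out lower numbers stand for higher toxicity in this test and higher numbers for lower toxicity in this test), compound 1 gives > 20 ug/mL, which is a limit of the assay.
Compound 2 `COC(=O)c1cc(-c2cccc(NC(=O)c3ccc(/C=C/C(=O)c4ccc(OC)c(OC)c4)cc3)c2)on1`: in this assay compound 2 gives > 50 ug/mL, likewise a limit.

In this assay, among the measured compounds shown here, compound 2 stands only at a limit, and the one other value shown is a limit as well. For the measured compounds named here, the single measured step, a step that the two limits leave unreadable from compound 1 to compound 2, rests on the limit of > 20 ug/mL in this assay, at which 1 of the 2 values shown sits, and (the limit of > 50 ug/mL in this assay, at which 1 of the 2 values shown sits), so it gives no readable size. Compound 3 `COC(=O)c1cc(-c2cccc(NC(=O)c3ccc(/C=C/C(=O)c4ccc(CC(C)C)cc4)cc3)c2)on1` differs from compound 2 by 4-isobutylphenyl in place of 3,4-dimethoxyphenyl on a carbonyl carbon. Going by the values given here, no measured step bears on this change, so no step beyond the scatter is expected in either direction. Compound 3 is expected at 50 ug/mL, within 15 ug/mL to 100 ug/mL. The expected step of a number no higher from compound 2 to compound 3 (the limit leaves the size open) thus means no change beyond the scatter.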

Compound 3, half-maximal cytotoxic concentration: > 10 ug/mL
Compound 3: no number, only a limit; the forecaster's own chance of this, stated with the estimate: 65%; the middle value does not contradict the limit.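

In this assay, compound 1, compound 2 and compound 3 all stand only at limits, and no step among these three compounds can be read. The compounds shown leave open whether exchanging 4-fluorophenyl, 3,4-dimethoxyphenyl and 4-isobutylphenyl on the carbonyl carbon changes the half-maximal cytotoxic concentration at all.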